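The source may report more compounds than this note shows. Statements on the series, on what has been measured and on what is new or still open speak of the compounds shown alone.

Measured compounds and their values in an ADME assay on HaCaT cells (Homo sapiens) for inhibition, read by sulforhodamine B assay, with a stated time of 48 h; a lower number here means a stronger inhibitor of growth, a higher number a weaker inhibitor of growth:
compound 1, `C=C(C)[C@@H]1CC=C(Cn2cc(COc3ccc(C4NC(=O)NC(C)=C4C(=O)OCC)cc3)nn2)CC1`, 166000 nM
compound 2, `C=C(C)[C@@H]1CC=C(Cn2cc(COc3ccccc3C3NC(=O)NC(C)=C3C(=O)OCC)nn2)CC1`, 294000 nM
compound 3, `C=C(C)[C@@H]1CC=C(Cn2cc(COc3ccc(C4NC(=O)NC(C)=C4C(C)=O)cc3)nn2)CC1`, 44500 nM

Compound 1 and compound 2 share the same atoms joined differently; the difference between the two cores is not broken down here. Their values in this assay lie within the usual scatter of each other, so no order between them is claimed. Compound 3 differs from compound 1 in one place, (methyl in place of ethoxy on a carbonyl carbon), and this change gave a 3.7-fold lower number from compound 1 to compound 3 (0.57 log units; beyond the scatter).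

Compound 4, `C=C(C)[C@@H]1CC=C(Cn2cc(COc3ccccc3C3NC(=O)NC(C)=C3C(C)=O)nn2)CC1`, has not yet been measured in this assay. Among the compounds with values here, it differs from compound 2 by methyl in place of ethoxy on a carbonyl carbon, the same change as the one from compound 1 to compound 3, made on the same kind of place. Because the step from compound 1 to compound 3 was a 3.7-fold lower number from compound 1 to compound 3 (0.57 log units; beyond the scatter), a step of similar size is expected from compound 2 to compound 4, namely a 3.7-fold lower number from compound 2 to compound 4 (0.57 log units; beyond the scatter). This rests on a single earlier instance of the change, so the range around the estimate is kept wide. With compound 2 at 294000 nM as the starting point, compound 4 is expected to give about 80000 nM in this assay, between 35000 nM and 200000 nM.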

Compound 4, concentration for total growth inhibition: 29500 nM
Estimate against measurement, compound 4: 2.7-fold (0.43 log units) above; measured number outside the range, below it.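

In this assay, replacing ethoxy with methyl on a carbonyl carbon, which turns the ethoxycarbonyl into an acetyl, gave a 10-fold lower number from compound 2 to compound 4 (1.00 log units; beyond the scatter), so the number fell on this core as it had on the core of compound 1. The direction of the change therefore carried from one core to the other, but its size did not, and the two steps differ by more than their combined scatter allows: the same change on two cores in this assay, a 3.7-fold lower number (0.57 log units; beyond the scatter) from compound 1 to compound 3 and a 10-fold lower number (1.00 log units; beyond the scatter) from compound 2 to compound 4, 2.7-fold (0.43 log units) apart, beyond the scatter of two such steps These two pairs show that a step measured on one core in this series cannot simply be transferred at full size to the other, but they do not explain why the size differs, and they offer no basis for predicting the size of the step on any further core.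

The compounds shown leave open how other groups on that carbonyl carbon would behave, such as hydroxy, which would give a carboxylic acid, an amine, which would give an amide, or a longer chain such as propyl in place of the methyl. They also leave open whether the larger step on the core of compound 2 would appear again with any of these groups, or whether it is particular to the acetyl.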